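A few compounds are considered here, and "the series" means these few. Any claim that something is new, unique, unknown or untested is made for them only; others in the source may bear on it.

Measured compounds:
compound 1, `Cc1ccc(NC(=O)c2cccc(/C=C3\CC(=O)N(c4ccccc4)C3=O)c2)cc1`: > 100000 nM
compound 2, `CCCCCN1C(=O)C/C(=C\c2cccc(C(=O)Nc3ccc(C)cc3)c2)C1=O`: > 100000 nM
compound 3, `COc1ccc(NC(=O)c2cccc(/C=C3\CC(=O)N(c4ccccc4)C3=O)c2)cc1`: > 100000 nM

All three were tested in an ADME assay on NCM460 cells (Homo sapiens) for cytotoxicity, read by MTT assay, with a stated time of 72 h; on this read-out higher numbers stand for weaker inhibition and lower numbers for stronger inhibition. Compound 2 stands at > 100000 nM, which is a limit of the assay and not a number. Compound 1 likewise gives > 100000 nM, a limit. Compound 3 gives > 100000 nM, again a limit. Because (the limit of > 100000 nM in this assay, at which 3 of the 3 values shown sit), none of the three can be placed relative to one another on this read-out.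

Compound 4, `CCCCCN1C(=O)C/C(=C\c2cccc(C(=O)Nc3cccc(CC)c3)c2)C1=O`, has not yet been measured in this assay. It differs from compound 2 in one place: 3-ethylphenyl in place of 4-methylphenyl on an amide-type nitrogen. Among the compounds with values here, only two measured steps are available for comparison, and neither alters the same group. The step that the two limits leave unreadable from compound 1 to compound 2 and the step that the two limits leave unreadable from compound 1 to compound 3 both run between limits, so their size cannot be read; they show only that each of the three compounds sits at the limit.

With three values at the limit and no readable step, compound 4 is expected to stay at the limit as well, the step of a number no higher from compound 2 to compound 4 (the limit leaves the size open) being the estimate. Compound 4 is therefore estimated at 100000 nM, with a range from 30000 nM to 300000 nM, and is expected most likely to be reported again only as a limit.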

Compound 4, half-maximal inhibitory concentration: > 100000 nM
Compound 4 gave a limit, no number (the forecaster's own chance of this, stated with the estimate: 85%); the middle value sits exactly at the limit.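

In this assay compound 4 gives > 100000 nM, a limit of the assay and not a number. Compound 2 also stands at a limit, and the step between compound 2 and compound 4 cannot be read. The compounds shown leave open how far each lies from that limit, and whether 3-ethylphenyl and 4-methylphenyl differ on this read-out at all.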